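A few compounds are considered here, and "the series" means these few. Any claim that something is new, unique, unknown or untested is made for them only; others in the source may bear on it.

Compounds measured so far in an ADME assay on the whole organism (serum) with Homo sapiens as the target; on this read-out lower numbers stand for a shorter-lived compound and higher numbers for a longer-lived compound:

Compound 1, `Cc1cn(C2CC(N=[N+]=[N-])C(COC(=O)CCCN)O2)c(=O)[nH]c1=O`, gives 0.433 h.
Compound 2, `Cc1cn(C2CC(N=[N+]=[N-])C(COC(=O)OCCCO)O2)c(=O)[nH]c1=O`, gives 0.167 h.
Compound 3, `Cc1cn(C2CC(N=[N+]=[N-])C(COC(=O)OCCCC(=O)O)O2)c(=O)[nH]c1=O`, gives 13 h.

Compound 3 stands highest of the three. The step to it from compound 1 is a 30-fold higher number from compound 1 to compound 3 (1.48 log units; beyond the scatter), and the step from compound 2 is a 78-fold higher number from compound 2 to compound 3 (1.89 log units; beyond the scatter); both lie beyond the scatter, so compound 3 is the longest-lived compound of this set.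

Compound 4, `Cc1cn(C2CC(N=[N+]=[N-])C(COC(=O)OCCCCCO)O2)c(=O)[nH]c1=O`, differs from compound 3 in one place: 2-hydroxyethyl in place of carboxy on a saturated chain carbon, three bonds along the chain from an oxygen next to a carbonyl group. The step that bears on this most directly is the one in the opposite direction, from compound 2 to compound 3, where a 78-fold higher number from compound 2 to compound 3 (1.89 log units; beyond the scatter) followed the exchange of hydroxy for carboxy on that same chain carbon. Compound 4 returns to a hydroxy-ended chain, so a large downward step in this assay is expected, roughly undoing that earlier gain. The smaller step of a 2.6-fold lower number from compound 1 to compound 2 (0.41 log units; beyond the scatter) also shows a hydroxy-ended ester chain sitting at the short end of the range.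

For compound 4 the expected step is a 52-fold lower number from compound 3 to compound 4 (1.72 log units; beyond the scatter), giving an estimated half-life of 0.25 h, with a range from 0.08 h to 1 h.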

Compound 4, half-life: 0.267 h
The estimate for compound 4 lay 1.1-fold (0.03 log units) below the measured number; the measured number falls inside the stated range.
By their numbers in this assay, from the lowest: compounds 2, 4 and 1 (each within the scatter of the next, the first and the last beyond it); then compound 3.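

In this assay, for the compounds shown here, the step of a 49-fold lower number from compound 3 to compound 4 (1.69 log units; beyond the scatter) shows that a chain ending in hydroxy stays short-lived even when it is longer than the one in compound 2, while the carboxy end of compound 3 stands apart. Chain length made no readable difference here: the gap a 1.6-fold higher number from compound 2 to compound 4 (0.20 log units; within the scatter) leaves these two hydroxy-ended chains indistinguishable. The carbonate of compound 4 and the amine-ended ester of compound 1 also cannot be told apart, with a 1.6-fold lower number from compound 1 to compound 4 (0.21 log units; within the scatter) as their step, so only compound 3 separates from the group of four.

As far as these compounds go, whether a carboxylic acid on a longer chain, or a methyl ester or amide at the chain end, would give a long half-life remains open. No available evidence explains why the carboxy end stands apart.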